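Chlorine position and thienyl exchange on the shared core

A few compounds are considered here, and "the series" means these few. Any claim that something is new, unique, unknown or untested is made for them only; others in the source may bear on it.

Measured in an ADME assay on HEK293 cells (Homo sapiens) for cytotoxicity, read by CCK-8 assay and cell counting, with a stated time of 2 days; on this read-out lower numbers stand for stronger inhibition and higher numbers for weaker inhibition:
compound 1 `Oc1cccc(-c2cc(-c3ccc(Cl)cc3)nc(-c3ccsc3)c2)c1`: 11200 nM
compound 2 `Oc1cccc(-c2cc(-c3ccsc3)nc(-c3cccc(Cl)c3)c2)c1`: 3180 nM
compound 3 `Oc1cccc(-c2cc(-c3ccsc3)nc(-c3ccccc3Cl)c2)c1`: 2720 nM

Compound 2 holds the second highest of the three numbers: the step of a 3.5-fold lower number from compound 1 to compound 2 (0.55 log units; beyond the scatter) lies beyond the scatter, while a 1.2-fold lower number from compound 2 to compound 3 (0.07 log units; within the scatter) lies within it. Compound 4 `Oc1cccc(-c2cc(-c3ccccc3)nc(-c3cccc(Cl)c3)c2)c1` differs from compound 2 by phenyl in place of thiophen-3-yl on an aromatic carbon. Among the measured compounds shown here, none of the measured steps touches this position: a 3.5-fold lower number from compound 1 to compound 2 (0.55 log units; beyond the scatter), a 4.1-fold lower number from compound 1 to compound 3 (0.61 log units; beyond the scatter) and a 1.2-fold lower number from compound 2 to compound 3 (0.07 log units; within the scatter) all move the chlorine on the chlorophenyl group and leave the thienyl untouched, so the record gives no direct guide. With the 3-chlorophenyl group kept from compound 2, no step beyond the scatter is expected in this assay in either direction. Compound 4 is accordingly estimated at 3200 nM, within 1200 nM to 8500 nM. That estimate amounts to a 1.0-fold higher number from compound 2 to compound 4 (0.00 log units; within the scatter).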

Compound 4, half-maximal inhibitory concentration: 3120 nM
The estimate for compound 4 lay 1.0-fold (0.01 log units) above the measured number, and the stated range covers the measured number.
By their numbers in this assay, from the lowest: compounds 3, 4 and 2 (each within the scatter of the next); then compound 1.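

Among the compounds shown here, with the 3-chlorophenyl group kept, phenyl in place of thiophen-3-yl next to the ring nitrogen gives a 1.0-fold lower number from compound 2 to compound 4 (0.01 log units; within the scatter) in this assay, the first step at this position, and it lies within the scatter. In this single pair, the read-out does not separate the two aromatic rings. Still open, going by these compounds, is whether the same holds with the 2-chlorophenyl or 4-chlorophenyl group in place, and what an amine or a carboxylic acid on this ring position would give. No measured property bears on this result.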